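Halogen at the Chain End: From Bromo to Iodo

This account rests on a few compounds, and the source may have more. Where it says the series, first, only, none or still open, it means among the compounds named here.

Three compounds share one core and differ only in the halogen at the far end of the chain. Compound 1 `O=c1[nH]c(=O)n([C@H]2C[C@H](O)[C@@H](CO)O2)cc1C#CCCCCCCCCCF` carries fluoro, compound 2 `O=c1[nH]c(=O)n([C@H]2C[C@H](O)[C@@H](CO)O2)cc1C#CCCCCCCCCCCl` chloro and compound 3 `O=c1[nH]c(=O)n([C@H]2C[C@H](O)[C@@H](CO)O2)cc1C#CCCCCCCCCCBr` bromo. In a functional assay on HEL cells (Homo sapiens) for cytotoxicity (a lower number here means that less compound is tolerated, a higher number that more compound is tolerated), compound 1 gives 116000 nM, compound 2 gives 74000 nM and compound 3 gives 97000 nM. The steps among them are small: a 1.6-fold lower number from compound 1 to compound 2 (0.20 log units; within the scatter), a 1.2-fold lower number from compound 1 to compound 3 (0.08 log units; within the scatter) and a 1.3-fold higher number from compound 2 to compound 3 (0.12 log units; within the scatter). Compound 3 therefore stands second highest of the three numbers, with compound 1 nearest and compound 2 furthest, and all three lie within the scatter of one another.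

Compound 4 `O=c1[nH]c(=O)n([C@H]2C[C@H](O)[C@@H](CO)O2)cc1C#CCCCCCCCCCI` continues the series with the next halogen. The change is iodo in place of bromo on a saturated chain carbon, nine bonds along the chain from a triple-bonded carbon. Going by the values given here, the steps that bear on it are the three halogen swaps already seen, fluoro to chloro, fluoro to bromo and chloro to bromo, none of which moved this assay beyond the scatter. A step in the same direction, bromo to iodo, is thus expected to give at most a change within the scatter for compound 4, with no clear direction. The estimate for compound 4 in this assay is 90000 nM, between 45000 nM and 180000 nM, corresponding to an expected step of a 1.1-fold lower number from compound 3 to compound 4 (0.03 log units; within the scatter).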

Compound 4, half-maximal cytotoxic concentration: 68000 nM
Compound 4: the middle estimate sits 1.3-fold (0.12 log units) above what was measured, and the stated range covers the measured number.
By their numbers in this assay, from the lowest: compounds 4, 2, 3 and 1 (each within the scatter of the next).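

Iodo completes the set of four halogens at this chain end, and it too leaves this assay within the scatter, whichever halogen it is compared with (a 1.4-fold lower number from compound 3 to compound 4 (0.15 log units; within the scatter); a 1.1-fold lower number from compound 2 to compound 4 (0.04 log units; within the scatter); a 1.7-fold lower number from compound 1 to compound 4 (0.23 log units; within the scatter)). The earlier compounds shown here covered only fluoro, chloro and bromo, whereas all six pairs among compounds 1, 2, 3 and 4 now lie within the scatter, including the pair of fluoro and iodo with the largest step, so no order among the four halogens can be read from these numbers and the halogen swap at this position has no resolved effect on the read-out. Nothing available explains why these numbers stay so close together.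

What the compounds shown leave open is whether a group of another kind at the same chain end, such as a hydroxyl, an amine or a carboxylic acid, would move the number beyond the scatter. They also leave open whether a shorter or longer chain carrying the same halogens would stay equally close in this assay as well.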